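This account rests on a few compounds, and the source may have more. Where it says the series, first, only, none or still open, it means among the compounds named here.

Of the compounds shown here, three built on one shared core have been tested in a functional assay on MDA-MB-231 cells (Homo sapiens) for cytotoxicity, read by MTT assay, with a stated time of 48 h; on this read-out higher numbers stand for weaker inhibition and lower numbers for stronger inhibition. Compound 1 `O=C1C[C@H](OCc2cn(Cc3ccccc3)nn2)[C@H]2CO[C@@H]1O2` reaches only a limit of the assay, > 50000 nM. Compound 2 `CCCCCCCCn1cc(CO[C@H]2CC(=O)[C@@H]3OC[C@H]2O3)nn1` likewise stops at a limit, > 50000 nM. Among the compounds with values here, compound 3 `C=C(C)Cn1cc(CO[C@H]2CC(=O)[C@@H]3OC[C@H]2O3)nn1` is the sole compound that gives an actual number in this assay, 26700 nM, so it alone marks a point on the scale, while the remaining two values are the limit of > 50000 nM in this assay, at which 2 of the 3 values shown sit. On these data alone, the step of an at least 1.8-fold lower number from compound 1 to compound 3 (0.27 log units; that floor lies within the scatter) and the step of an at least 1.8-fold lower number from compound 2 to compound 3 (0.27 log units; that floor lies within the scatter) are each read against a limit, so their true size stays open, and the step that the two limits leave unreadable from compound 1 to compound 2 cannot be read at all. Compound 4 `O=C1CCCCC1n1cc(CO[C@H]2CC(=O)[C@@H]3OC[C@H]2O3)nn1` keeps the core and changes only the group on the aromatic nitrogen: 2-oxocyclohexyl in place of 2-methylprop-2-en-1-yl on an aromatic nitrogen. Within the data shown here, no measured step covers a ring or a carbonyl entering at this spot, so no direction can be drawn from them. The expected change in this assay from compound 3 to compound 4, a 1.1-fold higher number from compound 3 to compound 4 (0.05 log units; within the scatter), is therefore set near none beyond the scatter, with wide uncertainty. Compound 4 is thus estimated at 30000 nM in this assay, between 8000 nM and 120000 nM.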

Compound 4, half-maximal inhibitory concentration: 36000 nM
Beside the measured number, compound 4's estimate is 1.2-fold (0.08 log units) below it; the range from low to high includes it.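

In this assay the step of a 1.3-fold higher number from compound 3 to compound 4 (0.13 log units; within the scatter) shows that a six-membered carbon ring bearing a carbonyl can replace the small 2-methylprop-2-en-1-yl chain on the aromatic nitrogen with no change beyond the scatter. Compound 4 is thus the second compound here to give an actual number rather than a limit, and the first with a non-aromatic ring directly on that nitrogen. On these data alone, the steps of an at least 1.3-fold lower number from compound 2 to compound 4 (0.14 log units; that floor lies within the scatter) and an at least 1.3-fold lower number from compound 1 to compound 4 (0.14 log units; that floor lies within the scatter) give only floors, and their true size stays open because compound 1 and compound 2 each stop at a limit: the limit of > 50000 nM in this assay, at which 2 of the 4 values shown sit.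

As far as these compounds go, whether plain cyclohexyl, the same ring without the carbonyl, would read any differently stays open, so the roles of the ring and the carbonyl cannot be told apart. Also open, from the compounds shown here alone, is whether an amine or a carboxylic acid on this ring would move the number beyond the scatter.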